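Bromo in Place of Methoxy on the Shared Core

The source may hold more compounds than are shown below. What is called first, only, known or untested is meant among the compounds shown, and "the series" means these compounds.

Compound 2 `COc1ccc(C2=Nn3c(nnc3C(C)c3ccc(-c4ccccc4)c(F)c3)SC2)cc1`: 4200 nM
Compound 1 `CC(C)Cc1ccc(C(C)c2nnc3n2N=C(c2ccc(OC(F)(F)F)cc2)CS3)cc1`: 9700 nM

In a functional assay on HepG2 cells (Homo sapiens) for inhibition, read by sulforhodamine B assay, with a stated time of 72 h (on this read-out higher numbers stand for weaker inhibition and lower numbers for stronger inhibition), compound 2 gives 4200 nM, the lowest of the two numbers; compound 1 gives 9700 nM, a higher number beyond the scatter. Compound 3 `CC(c1ccc(-c2ccccc2)c(F)c1)c1nnc2n1N=C(c1ccc(Br)cc1)CS2` has not been measured. It differs from compound 2 in one place: bromo in place of methoxy on an aromatic carbon. Going by the values given here, no measured pair shows this change, so its effect is unknown. In this assay the expected step is a 1.1-fold lower number from compound 2 to compound 3 (0.02 log units; within the scatter), none beyond the scatter in either direction. Compound 3 is estimated at 4000 nM, with a range from 1500 nM to 11000 nM.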

Compound 3, half-maximal inhibitory concentration: 3700 nM
Estimate against measurement, compound 3: 1.1-fold (0.03 log units) above; the range from low to high includes it.
By their numbers in this assay, from the lowest: compounds 3 and 2 (each within the scatter of the next); then compound 1.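

In this assay bromo in place of methoxy on an aromatic carbon gives a 1.1-fold lower number from compound 2 to compound 3 (0.06 log units; within the scatter) and so the read-out does not separate 4-methoxyphenyl from 4-bromophenyl on the shared core. This pair isolates that one place, which compound 1 could not do because it differs from compound 2 in more than one place. Nothing measured here offers an explanation for this result. The compounds shown leave open whether an amine or a carboxylic acid at this place would move the number beyond the scatter.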